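A urea-to-amide exchange on a shared pyrazole-bearing core

A few compounds are considered here, and "the series" means these few. Any claim that something is new, unique, unknown or untested is made for them only; others in the source may bear on it.

Compounds measured so far:
compound 1, `O=C(Nc1cccc(-n2cc(-c3ccncc3)c(-c3cc(O)cc(Cl)c3)n2)c1)Nc1ccc(Cl)c(Cl)c1`: -52%
compound 2, `COc1cc(Cl)cc(-c2nn(-c3cccc(NC(=O)Nc4ccc(Cl)c(Cl)c4)c3)cc2-c2ccncc2)c1`: -43%

In a functional assay on RXF 393 cells (Homo sapiens) for inhibition, read by sulforhodamine B assay, with a stated time of 48 h, tested at 100 uM (a higher number here means a weaker effect of the compound at the concentration tested, a lower number a stronger effect), compound 1 gives -52%, and in this assay compound 2 gives -43%. Among the compounds with values here, the only measured step is a number 9 percentage points higher from compound 1 to compound 2 (within the scatter), a change of methyl in place of hydrogen on an oxygen on an aromatic ring. Compound 2 stands highest of the two numbers, with compound 1 nearest, and as that gap is within the scatter no order between them can be claimed.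

Compound 3, `COc1cc(Cl)cc(-c2nn(-c3cccc(NC(=O)c4cccc(C(F)(F)F)c4)c3)cc2-c2ccncc2)c1`, has not yet been measured in this assay. It differs from compound 2 by 3-(trifluoromethyl)phenyl in place of (3,4-dichlorophenyl)amino on a carbonyl carbon. Within the data shown here, no measured step bears on this change: the one step on record concerns a different part of the molecule, and nothing in the data shows what removing the (3,4-dichlorophenyl)amino group from the carbonyl carbon does. The expectation therefore rests on the two values alone, with wide uncertainty in both directions.

For compound 3 in this assay a value of -30% is estimated, expected to fall between -70% and 15%. This corresponds to an expected step of a number 13 percentage points higher from compound 2 to compound 3 (beyond the scatter), with no confident direction beyond the scatter.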

Compound 3, a percentage reported as activity, at one concentration (the size of the read-out at that concentration, not a potency): 19%
Beside the measured number, compound 3's estimate is 49 percentage points below it; measured number above the stated range.
By their numbers in this assay, from the lowest: compounds 1 and 2 (each within the scatter of the next); then compound 3.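

Placing 3-(trifluoromethyl)phenyl on the carbonyl carbon in place of (3,4-dichlorophenyl)amino, which turns the urea into an amide, gives a large step in this assay, a number 62 percentage points higher from compound 2 to compound 3 (beyond the scatter), so this position strongly affects the read-out. The sign of the read-out also differs, with compound 2 at -43% and compound 3 at 19%, whereas the earlier change on the aromatic oxygen, a number 9 percentage points higher from compound 1 to compound 2 (within the scatter), had shown no effect that could be told from the scatter. No measurement available here accounts for the size of this step.

The exchange alters the link and the ring substituents together, so the compounds shown leave open whether the weaker effect follows the loss of the urea nitrogen or the exchange of the two chlorines for trifluoromethyl; a 3,4-dichlorobenzoyl amide and a urea carrying 3-(trifluoromethyl)phenyl on its nitrogen would separate the two. As far as these compounds go, it also remains open whether a hydroxyl in place of the methoxy on the shared core would leave the amide series as little changed as it left the urea pair.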